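Naphthalenyl in place of phenoxymethyl on the chain

The source may hold more compounds than are shown below. What is called first, only, known or untested is meant among the compounds shown, and "the series" means these compounds.

Three compounds have been examined in an assay on CHO cells for displacement of a labelled ligand from prostaglandin E2 receptor EP1 subtype (Mus musculus), read by scintillation counting; on this read-out higher numbers stand for weaker inhibition and lower numbers for stronger inhibition. Compound 1 `Cc1ccc(/C=C/C(=O)O)c(OCCC2(C)CCc3c(C)c(O)c(C)c(C)c3O2)c1` gives only a limit of the assay, > 10000 nM. The step that the two limits leave unreadable from compound 1 to compound 2 replaces methyl with methoxy on an aromatic carbon, and its size cannot be read because both ends are limits. Compound 2 `COc1ccc(/C=C/C(=O)O)c(OCCC2(C)CCc3c(C)c(O)c(C)c(C)c3O2)c1` likewise gives only a limit, > 10000 nM. Compound 3 `O=C(O)/C=C/c1ccc(Cn2ccnc2)cc1OCCCOc1ccccc1` stands at the same place: its result in this assay is also a limit, > 10000 nM. Going by the values given here, every value so far sits at the limit of > 10000 nM in this assay, at which 3 of the 3 values shown sit, so compound 3 has no number of its own to be placed against the others.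

Compound 4 `O=C(O)/C=C/c1ccc(Cn2ccnc2)cc1OCCc1ccc2ccccc2c1` differs from compound 3 by naphthalen-2-yl in place of phenoxymethyl on a saturated chain carbon, two bonds along the chain from an oxygen on an aromatic ring. Among the compounds with values here, no measured step touches this kind of change, and the only measured step, from compound 1 to compound 2, is itself unreadable. Compound 4 is therefore expected to remain at the limit, with an estimated value of 15000 nM spanning 3000 nM to 60000 nM. The expected step that the limit leaves unreadable from compound 3 to compound 4 is thus no readable change.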

Compound 4, inhibition constant: > 10000 nM
Compound 4 gave a limit, no number; the forecaster's own chance of this, stated with the estimate: 80%; the middle value lies beyond the limit too.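

Compound 3 and compound 4 both give only a limit in this assay, so no step between them can be read: the limit of > 10000 nM in this assay, at which 4 of the 4 values shown sit.

The compounds shown leave open whether naphthalen-2-yl and phenoxymethyl on the chain differ at all in inhibition, and what structure would give a measurable value.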